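A few compounds are considered here, and "the series" means these few. Any claim that something is new, unique, unknown or untested is made for them only; others in the source may bear on it.

Measured in a functional assay on THP-1 cells (Homo sapiens) for inhibition, with a stated time of 4 h; a higher number here means a weaker inhibitor, a lower number a stronger inhibitor:
Compound 1 `O=C(CN1CCCN(C(=O)c2ccccc2)C[C@H](NC(=O)c2ccccc2)C1=O)N[C@H]1CC(=O)OC1O`: 1020 nM
Compound 2 `O=C(CN1CCCN(C(=O)c2ccccc2)C[C@H](NC(=O)c2cccc(C(F)(F)F)c2)C1=O)N[C@H]1CC(=O)OC1O`: 1020 nM

Among the compounds with values here, compound 2 stands level with compound 1, the only other measured compound. Compound 3 `Cc1ccc(Cl)cc1C(=O)N[C@H]1CN(C(=O)c2ccccc2)CCCN(CC(=O)N[C@H]2CC(=O)OC2O)C1=O` alters the aromatic group on a carbonyl carbon whose other neighbour is an amide-type nitrogen: 5-chloro-2-methylphenyl in place of 3-(trifluoromethyl)phenyl on a carbonyl carbon. Within the data shown here, the one measured step bearing on this group is the addition of trifluoromethyl to its aromatic ring, which gave no change at the digits printed from compound 1 to compound 2 (within the scatter). A single step is thin evidence, but it points to no shift beyond the scatter in this assay, and no direction is favoured, so the expected step is a 1.0-fold lower number from compound 2 to compound 3 (0.01 log units; within the scatter). For compound 3 the estimated value is 1000 nM, with an expected range of 400 nM to 2500 nM.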

Compound 3, half-maximal inhibitory concentration: 298 nM
Estimate against measurement, compound 3: 3.4-fold (0.53 log units) above; measured number outside the range, below it.
By their numbers in this assay, from the lowest: compound 3; then compounds 1 and 2 (each within the scatter of the next).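

The aromatic group on this carbonyl carbon can clearly alter the result in this assay: 5-chloro-2-methylphenyl gives a 3.4-fold lower number from compound 2 to compound 3 (0.53 log units; beyond the scatter) and, set against plain phenyl, a 3.4-fold lower number from compound 1 to compound 3 (0.53 log units; beyond the scatter). The flat outcome with trifluoromethyl therefore did not mean that this position is indifferent to what it carries. Nothing measured here accounts for the difference.

Chlorine and methyl enter together, so the share of each stays open. Also open, on these data alone, is whether a ring bearing only one of them, or a methoxy group or nitrile instead, would behave the same way.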